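From 4-methylphenyl to 4-fluorophenyl: one substituent exchanged

A few compounds are considered here, and "the series" means these few. Any claim that something is new, unique, unknown or untested is made for them only; others in the source may bear on it.

Three compounds have been measured so far in a functional assay on MCF7 cells (Homo sapiens) for cytotoxicity, read by MTT assay, with a stated time of 96 h (on this read-out lower numbers stand for stronger inhibition and higher numbers for weaker inhibition), and give these values:

Compound 1 `COc1cc(C(=O)c2cn(-c3ccccc3)cc2-c2ccccc2Cl)cc(OC)c1OC` gives 76 nM
Compound 2 `COc1cc(C(=O)c2cn(-c3cccc(C)c3)cc2-c2ccccc2Cl)cc(OC)c1OC` gives 420 nM
Compound 3 `COc1cc(C(=O)c2cn(-c3ccc(C)cc3)cc2-c2ccccc2Cl)cc(OC)c1OC` gives 180 nM

Compound 3 stands in the middle of these three numbers, with clear steps on both sides (a 2.4-fold higher number from compound 1 to compound 3 (0.37 log units; beyond the scatter); a 2.3-fold lower number from compound 2 to compound 3 (0.37 log units; beyond the scatter)). Compound 4 `COc1cc(C(=O)c2cn(-c3ccc(F)cc3)cc2-c2ccccc2Cl)cc(OC)c1OC` has not yet been measured. It differs from compound 3 by fluoro in place of methyl on an aromatic carbon, para to a large group (fluoro in place of methyl on an aromatic carbon).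

The step that bears most directly on this change is the one that put that same methyl onto compound 1 (a 2.4-fold higher number from compound 1 to compound 3 (0.37 log units; beyond the scatter)). The other methyl step is larger (a 5.5-fold higher number from compound 1 to compound 2 (0.74 log units; beyond the scatter)), but it concerns the 3-methylphenyl compound and so bears only on how much the place of the methyl matters. For the measured compounds named here, no measured compound carries fluoro, so the effect of its entry remains unknown. Removing the methyl may recover part of the modest rise seen from compound 1. For compound 4, the expected step in this assay is small and toward a lower number (a 1.8-fold lower number from compound 3 to compound 4 (0.26 log units; within the scatter)). For compound 4, the estimated value is 100 nM, with an expected range from 40 nM to 250 nM.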

Compound 4, half-maximal inhibitory concentration: 83 nM
The estimate for compound 4 lay 1.2-fold (0.08 log units) above the measured number; measured number inside the range.
By their numbers in this assay, from the lowest: compounds 1 and 4 (each within the scatter of the next); then compound 3; then compound 2.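

In this assay, exchanging 4-methylphenyl for 4-fluorophenyl gives a step beyond the scatter (a 2.2-fold lower number from compound 3 to compound 4 (0.34 log units; beyond the scatter)), which shows that this place distinguishes between substituents and does not penalise every replacement of hydrogen. Fluoro in this place leaves the number within the scatter of the unsubstituted compound (a 1.1-fold higher number from compound 1 to compound 4 (0.04 log units; within the scatter)), so compound 1 and compound 4 cannot be told apart here, whereas the methyl of compound 3 stood clearly apart from compound 1. The step from the 3-methylphenyl compound is larger still (a 5.1-fold lower number from compound 2 to compound 4 (0.70 log units; beyond the scatter)), and among these four compounds only the two methyl compounds stand apart from compound 1.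

From the compounds shown here alone, whether a methoxy group, a chlorine atom or an amine in this same place would also stay level with compound 1 remains open, as does whether the fluoro result would carry over to the place held by methyl in compound 2. Nothing shown here accounts for the difference between fluoro and methyl in this place.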